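Adding an amino group to compound 1

The compounds below may be only part of what the source reports. "The series", "measured", "known", "first", "only" and "open" are said of these compounds alone.

In a physicochemical assay for lipophilicity, read by HPLC, in phosphate buffer, measured as octanol-water partition, with a stated time of 1 h, at pH 7.4 (a lower number here means a more polar compound, a higher number a more lipophilic compound), compound 1 (`C[C@@]1(c2cc(NC(=O)c3cnc(OCF)cn3)ccc2F)C=C(CF)OC(N)=N1`) stands at 2.6 as the higher of two numbers, and compound 2 (`CC1=C[C@@](C)(c2cc(NC(=O)c3ccc(C#N)cn3)ccc2F)N=C(N)O1`) gives 2.2 which lies lower, beyond the scatter. Compound 3 (`C[C@@]1(c2cc(NC(=O)c3ncc(OCF)nc3N)ccc2F)C=C(CF)OC(N)=N1`) differs from compound 1 by one change: amino in place of hydrogen on an aromatic carbon with amino in place of hydrogen on an aromatic carbon, next to the ring nitrogen and ortho to a large group. Going by the values given here, no measured pair shows this change, so only a small fall is expected in this assay and the estimated a number 0.10 log units lower from compound 1 to compound 3 (within the scatter) stays within the scatter. The expected value for compound 3 is 2.5 with an estimated range from 2.1 to 2.9 on this reasoning.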

Compound 3, distribution coefficient: 3.1
Beside the measured number, compound 3's estimate is 0.60 log units below it; measured number above the stated range.
By their numbers in this assay, from the lowest: compound 2; then compound 1; then compound 3.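

In this assay, going by these compounds alone, amino in place of hydrogen on an aromatic carbon, next to the ring nitrogen and ortho to a large group, gives a number 0.50 log units higher from compound 1 to compound 3 (beyond the scatter) as the only measured step at this position. The direction of this single step is upward, and compound 1 and compound 2 alone could not show this. Nothing measured here accounts for the rise.

Open, as far as these compounds go, is whether a methylamino or hydroxyl group at this position moves the number the same way. Also open, from the compounds shown here alone, is whether amino does so when a group other than fluoromethoxy sits on the ring.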